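Chloro and Nitro Replace Methyl: Expected Change in Cytotoxicity

This account rests on a few compounds, and the source may have more. Where it says the series, first, only, none or still open, it means among the compounds named here.

Of the compounds shown here, three that share one core have been measured in an ADME assay on MT4 cells (Homo sapiens) for cytotoxicity, read by MTT assay; on this read-out lower numbers stand for higher toxicity in this test and higher numbers for lower toxicity in this test. Compound 1 `Cc1cccc(C(=O)N(C(=S)OCCN2C(=O)c3ccccc3C2=O)c2ccc(Cl)cc2)c1` gives 58000 nM, the highest of the three numbers, although compound 3 sits within the scatter of it. Compound 2 `O=C1c2ccccc2C(=O)N1CCOC(=S)N(C(=O)c1cccc([N+](=O)[O-])c1)c1ccc(Cl)cc1` gives 18000 nM, and compound 3 `O=C1c2ccccc2C(=O)N1CCOC(=S)N(C(=O)c1cc([N+](=O)[O-])ccc1Cl)c1ccc(Cl)cc1` gives 45000 nM. The step of a 3.2-fold lower number from compound 1 to compound 2 (0.51 log units; beyond the scatter) lies beyond the scatter, the step of a 1.3-fold lower number from compound 1 to compound 3 (0.11 log units; within the scatter) lies within it, and the step of a 2.5-fold higher number from compound 2 to compound 3 (0.40 log units; beyond the scatter) lies beyond it again.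

Compound 4 `O=C1c2ccccc2C(=O)N1CCOC(=S)N(C(=O)c1ccc(Cl)c([N+](=O)[O-])c1)c1ccc(Cl)cc1` has not yet been measured in this assay. Relative to compound 1 it changes at one place: 4-chloro-3-nitrophenyl in place of 3-methylphenyl on a carbonyl carbon. For the measured compounds named here, two measured steps bear on this change. Going by the values given here, the step of a 3.2-fold lower number from compound 1 to compound 2 (0.51 log units; beyond the scatter) brings in the nitro alone; the step of a 1.3-fold lower number from compound 1 to compound 3 (0.11 log units; within the scatter) brings in a ring that, like the one entering compound 4, carries both chloro and nitro, though as another isomer. Compound 4 is therefore expected to fall between these two outcomes, and the expected step of a 1.7-fold lower number from compound 1 to compound 4 (0.22 log units; within the scatter) is a modest move toward a lower number, possibly not beyond the scatter. Compound 4 is estimated at 35000 nM, with a range from 15000 nM to 80000 nM.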

Compound 4, half-maximal cytotoxic concentration: 48000 nM
The estimate for compound 4 lay 1.4-fold (0.14 log units) below the measured number; the range from low to high includes it.
By their numbers in this assay, from the lowest: compound 2; then compounds 3, 4 and 1 (each within the scatter of the next).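

In this assay, putting 4-chloro-3-nitrophenyl on the carbonyl carbon gives a 1.2-fold lower number from compound 1 to compound 4 (0.08 log units; within the scatter), so this ring cannot be told apart from the 3-methylphenyl it replaces. The two chloro-nitro rings also cannot be told apart, with a 1.1-fold higher number from compound 3 to compound 4 (0.03 log units; within the scatter), and the arrangement of these two groups on the ring therefore makes no readable difference across this pair. The new result does show that compound 2, whose ring carries nitro without chloro, is the one that stands apart: a 2.7-fold higher number from compound 2 to compound 4 (0.43 log units; beyond the scatter) is a step beyond the scatter and runs the same way as a 2.5-fold higher number from compound 2 to compound 3 (0.40 log units; beyond the scatter), so adding chloro to the nitro ring goes with a higher number in both cases.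

No measurement shown here explains why adding chloro to the nitro ring goes with a higher number. From the compounds shown here alone, it also remains open whether the same would hold with a carboxylic acid or an amine in place of the nitro, or with chloro alone on this ring.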